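Taking one chlorine off the dichlorophenyl compound

The source may report more compounds than this note shows. Statements on the series, on what has been measured and on what is new or still open speak of the compounds shown alone.

Measured so far in an ADME assay on L6 cells (Rattus norvegicus) for cytotoxicity, read by resazurin assay, with a stated time of 70 h (on this read-out higher numbers stand for weaker inhibition and lower numbers for stronger inhibition), so far:
- compound 1 `CC(=O)Oc1ccc2c(c1)C(C)=CC(C)(C)N2Cc1ccc(C#N)cc1` gives 29000 nM
- compound 2 `CC(=O)Oc1ccc2c(c1)C(C)=CC(C)(C)N2Cc1ccc(C)cc1` gives 21000 nM
- compound 3 `CC(=O)Oc1ccc2c(c1)C(C)=CC(C)(C)N2Cc1ccc(Cl)c(Cl)c1` gives 28000 nM

These three values lie within the usual scatter of one another, so compound 3 (28000 nM) cannot be ranked and sits level with compound 1 and compound 2.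

The next compound, compound 4 `CC(=O)Oc1ccc2c(c1)C(C)=CC(C)(C)N2Cc1cccc(Cl)c1`, differs from compound 3 in one place. The difference is hydrogen in place of chloro on an aromatic carbon and it amounts to hydrogen in place of chloro on an aromatic carbon, turning 3,4-dichlorophenyl into 3-chlorophenyl. Among the measured compounds shown here, no measured pair makes exactly this change, so the nearest evidence comes from other changes on the same aromatic group. Going a 1.0-fold lower number from compound 1 to compound 3 (0.02 log units; within the scatter) and going a 1.3-fold higher number from compound 2 to compound 3 (0.12 log units; within the scatter) both swap the whole group for 3,4-dichlorophenyl. Going a 1.4-fold lower number from compound 1 to compound 2 (0.14 log units; within the scatter) puts methyl in place of cyano. Each of these steps is small, and none of the three compounds goes against that picture. No step beyond the scatter is therefore expected in this assay here. The expected change is a 1.0-fold lower number from compound 3 to compound 4 (0.02 log units; within the scatter) and this is an estimate only. The expected value for compound 4 is 27000 nM with an estimated range from 14000 nM to 50000 nM in repeat measurements.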

Compound 4, half-maximal inhibitory concentration: 29000 nM
Compound 4: middle estimate off by 1.1-fold (0.03 log units), on the low side; the measured number falls inside the stated range.
By their numbers in this assay, from the lowest: compounds 2, 3, 1 and 4 (each within the scatter of the next).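

In this assay, taking away one chloro group to turn 3,4-dichlorophenyl into 3-chlorophenyl gives a 1.0-fold higher number from compound 3 to compound 4 (0.02 log units; within the scatter). Among the compounds shown here, this is the first reading of a change at a single position on this aromatic ring, as the earlier steps swapped the whole group or put methyl in place of cyano, and this chloro group makes no difference that can be told from the scatter. The new compound also sits level with the other two, with a 1.4-fold higher number from compound 2 to compound 4 (0.14 log units; within the scatter) and no change at the digits printed from compound 1 to compound 4 (within the scatter), so 3-chlorophenyl, 4-methylphenyl, 4-cyanophenyl and 3,4-dichlorophenyl cannot be ranked here, and nothing measured on these compounds offers a reason for this flat picture.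

Going by these compounds, all four compounds share the same core, and the substituents seen on the aromatic ring are only chloro, methyl and cyano, so it remains open whether an amine or a carboxylic acid on that ring would shift the number beyond the scatter. On these data alone, it is equally open whether a plain phenyl ring with no substituent, or a longer chain in place of the single carbon linking the ring to the nitrogen, would stay level with these four.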